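The source may report more compounds than this note shows. Statements on the series, on what has been measured and on what is new or still open speak of the compounds shown alone.

Measured so far:
Compound 1 `COCCOC(=O)c1cc(N)c(Nc2ccc(C#N)cc2)cc1Oc1c(C)cc(/C=C/C#N)cc1C` gives 1.64 ug/mL.
Compound 2 `Cc1cc(/C=C/C#N)cc(C)c1Oc1cc(Nc2ccc(C#N)cc2)c(N)cc1C(=O)NN` gives 89.6 ug/mL.

For the measured compounds named here, in a physicochemical assay for solubility, read by HPLC, with a stated time of 4 h, at pH 2 (on this read-out lower numbers stand for lower solubility and higher numbers for higher solubility), compound 2 stands highest of the two numbers; the only measured step is a 55-fold higher number from compound 1 to compound 2 (1.74 log units; beyond the scatter). Compound 3 `Cc1cc(/C=C/C#N)cc(C)c1Oc1cc(Nc2ccc(C#N)cc2)c(N)cc1C(=O)NCCC(F)F` differs from compound 2 by 3,3-difluoropropyl in place of amino on an amide-type nitrogen. Going by the values given here, no measured pair shows this exact exchange; the one known step alters the other side of the same carbonyl and was large, so a large step is plausible here too. A fall is expected, a 15-fold lower number from compound 2 to compound 3 (1.17 log units; beyond the scatter), and compound 3 is estimated at 6 ug/mL, with a range from 1.5 ug/mL to 25 ug/mL.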

Compound 3, solubility: 57.6 ug/mL
Compound 3: the middle estimate sits 9.6-fold (0.98 log units) below what was measured; measured number above the stated range.
By their numbers in this assay, from the lowest: compound 1; then compounds 3 and 2 (each within the scatter of the next).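

Swapping amino for 3,3-difluoropropyl on the amide-type nitrogen gives a 1.6-fold lower number from compound 2 to compound 3 (0.19 log units; within the scatter) in this assay, so these two groups cannot be told apart in this test. Replacing 2-methoxyethoxy on the carbonyl carbon with (3,3-difluoropropyl)amino still gives a 35-fold higher number from compound 1 to compound 3 (1.55 log units; beyond the scatter), so the large step seen earlier is not tied to aminoamino alone. No evidence is available on the reason for this result. As far as these compounds go, it remains open whether plain propyl, a longer chain, or a chain ending in an amine or a carboxylic acid on that nitrogen would read the same.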